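The source may hold more compounds than are shown below. What is called first, only, known or untested is meant among the compounds shown, and "the series" means these compounds.

Measured so far:
Compound 1 `NC(=O)c1cccc(NC(=O)c2cc3ccccc3s2)c1`: in a physicochemical assay for solubility (a higher number here means a more soluble compound, a lower number a less soluble compound), compound 1 sits at the limit < 5 ug/mL.
Compound 2 `CC(C)(C)OC(=O)NCc1ccccc1NC(=O)c1ccc2ccccc2n1`: in this assay compound 2 likewise sits at the limit < 5 ug/mL.

Compound 2 therefore stands at the floor of what this assay reports. Its value is a limit rather than a number, and the other measured compound shares the same position, as the summary the limit of < 5 ug/mL in this assay, at which 2 of the 2 values shown sit, states. Among the compounds with values here, no step between two measured compounds is available, so the account has nothing measured to rest on beyond these two floors.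

Compound 3 `NCc1ccccc1NC(=O)c1ccc2ccccc2n1` has not yet been measured in this assay. It differs from compound 2 in a single place: hydrogen in place of tert-butoxycarbonyl on an amine nitrogen. Put otherwise, the ((tert-butoxycarbonyl)amino)methyl of compound 2 becomes aminomethyl in compound 3, with the rest of the molecule untouched.

Compound 2 gives only the limit < 5 ug/mL. A measured number for compound 3 would therefore be the first number in this assay among these compounds, and the step from compound 2 to compound 3 can be stated only as an expectation. An upward step from compound 2 to compound 3 that is expected to be well beyond the scatter is written as an at least 12-fold higher number from compound 2 to compound 3 (1.07 log units; beyond the scatter). On that basis compound 3 is estimated to reach 60 ug/mL, with a plausible range from 8 ug/mL to 400 ug/mL.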

Compound 3, solubility: 25 ug/mL
Compound 3: middle estimate off by 2.4-fold (0.38 log units), on the high side; measured number inside the range.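

Within the data shown here, compound 3 is the first compound here to give a number rather than a limit in this assay, so the position carrying the amine nitrogen is now known to be one where a single change can lift a compound off the floor of the read-out. With hydrogen in place of tert-butoxycarbonyl on that nitrogen, and the rest of the molecule untouched, the change gives an at least 5.0-fold higher number from compound 2 to compound 3 (0.69 log units; beyond the scatter), a step that the two earlier floor values could not provide. Compound 2 still gives only a limit, so this step fixes a smallest size and no largest one, and its true size remains unknown: the limit of < 5 ug/mL in this assay, at which 2 of the 3 values shown sit.

The compounds shown cannot separate what the loss of the tert-butoxycarbonyl contributes from what the aminomethyl contributes, and they do not show whether another group on the same nitrogen, such as acetyl or methyl, would also leave the floor. Nor do they show how a dimethylamine, a carboxylic acid or a longer chain ending in an amine would read at this position on the same core.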